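From Sec-Butyl to Cyclobutyl on the Ester Oxygen

The source may hold more compounds than are shown below. What is called first, only, known or untested is meant among the compounds shown, and "the series" means these compounds.

Measured compounds:
compound 1, `CC1=C(C(=O)OCc2ccccc2)C(c2ccoc2)NC(=O)N1`, gives 6650 nM in an assay on membranes from HEK293 cells for displacement of a labelled ligand from adenosine receptor A2b (Homo sapiens), read by scintillation counting, with a stated time of 30 min; on this read-out lower numbers stand for stronger inhibition and higher numbers for weaker inhibition;
compound 2, `CCC(C)OC(=O)C1=C(C)NC(=O)NC1c1ccoc1`, gives 201 nM in this assay.

For the measured compounds named here, compound 2 holds the lower of the two numbers, and its only neighbour, compound 1, sits far above it. Going by the values given here, the single measured step, a 33-fold lower number from compound 1 to compound 2 (1.52 log units; beyond the scatter), came from putting sec-butyl in place of benzyl on an oxygen next to a carbonyl group, so a large gain followed when the aromatic ring left that position.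

Compound 3, `CC1=C(C(=O)OC2CCC2)C(c2ccoc2)NC(=O)N1`, differs from compound 2 by cyclobutyl in place of sec-butyl on an oxygen next to a carbonyl group. The measured step replaced an aromatic group with an open chain; here a four-carbon chain is exchanged for a four-carbon ring of the same size and the same count of donors and acceptors. Among the compounds with values here, no measured pair covers such an exchange, so the one known step gives only weak guidance. The expectation is therefore a small step in this assay, not beyond the scatter, which is what a 1.2-fold higher number from compound 2 to compound 3 (0.09 log units; within the scatter) is meant to express. Compound 3 is expected to give 250 nM, with a range from 80 nM to 800 nM.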

Compound 3, inhibition constant: 307 nM
Compound 3: the middle estimate sits 1.2-fold (0.09 log units) below what was measured; the measured number falls inside the stated range.
By their numbers in this assay, from the lowest: compounds 2 and 3 (each within the scatter of the next); then compound 1.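

In this assay, the exchange of sec-butyl for cyclobutyl on the oxygen next to a carbonyl group gives a 1.5-fold higher number from compound 2 to compound 3 (0.18 log units; within the scatter), so at this position the open chain and the four-membered ring cannot be told apart. Cyclobutyl in place of benzyl gives a 22-fold lower number from compound 1 to compound 3 (1.34 log units; beyond the scatter), which shows that the wide gap to compound 1 is not special to sec-butyl: it appears with a ring as well as with an open chain, although only these three groups have been compared. Nothing available here explains why benzyl stands so far from the other two groups.

The compounds shown leave open whether a shorter group such as methyl, a longer chain such as hexyl, or a larger ring such as cyclohexyl on this oxygen would sit with compound 2 and compound 3 or closer to compound 1. They also leave open what a chain ending in an amine or a carboxylic acid would do there, and whether benzyl's large gap belongs to its aromatic ring or to the whole group, a question that phenyl or cyclohexylmethyl at this position could help to answer.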